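From 4-chlorophenyl to phenyl: what compound 4 may show

The source may hold more compounds than are shown below. What is called first, only, known or untested is meant among the compounds shown, and "the series" means these compounds.

Three compounds have numbers in a functional assay on HCT-15 cells (Homo sapiens) for cytotoxicity (a higher number here means a weaker inhibitor, a lower number a stronger inhibitor), so far. Compound 1 `Cc1ccc2c(S)nc(-c3ccccc3)cc2c1` gives 19100 nM; 41900 nM (2 entries) and so has no single number. Compound 2 `Cc1ccc2c(N3CCN(C)CC3)nc(-c3ccccc3C)cc2c1` stands at 77600 nM in a single entry. Compound 3 `CN1CCN(c2nc(-c3ccc(Cl)cc3)cc3c(N(C)C)cccc23)CC1` stands at 7980 nM as the lowest of the two single numbers, and compound 2 lies higher by a gap beyond the scatter.

Compound 4 `CN1CCN(c2nc(-c3ccccc3)cc3c(N(C)C)cccc23)CC1` has yet to be measured in this assay and differs from compound 3 in one place hydrogen in place of chloro on an aromatic carbon with hydrogen in place of chloro on an aromatic carbon, para to a large group, so that 4-chlorophenyl becomes phenyl.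

Going by the values given here, no measured pair isolates this change. Compound 1 at 19100 nM; 41900 nM (2 entries) carries no chloro, and neither does compound 2 at 77600 nM. Compound 3 stands at 7980 nM, and the numbers of compound 1 and compound 2 both lie higher even though these two compounds also differ from it elsewhere, which makes this only a weak guide.

A modest step of a 2.3-fold higher number from compound 3 to compound 4 (0.35 log units; beyond the scatter) is therefore expected, towards a higher number and a weaker inhibitor, and a little beyond the scatter. Compound 4 is expected near 18000 nM as the estimated value, with 7000 nM to 45000 nM as its estimated range.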

Compound 4, half-maximal inhibitory concentration: 20000 nM
Estimate against measurement, compound 4: 1.1-fold (0.05 log units) below, within the range that was stated.
By their numbers in this assay, from the lowest: compound 3; then compound 4; then compound 2.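

In this assay, going by these compounds alone, compound 3 and compound 4 form the first pair that differs in one place only, so the effect of hydrogen in place of chloro on an aromatic carbon, para to a large group, can now be read directly: the change from 4-chlorophenyl to phenyl gives a 2.5-fold higher number from compound 3 to compound 4 (0.40 log units; beyond the scatter). The earlier compounds shown here lacked the chloro but also differed from compound 3 elsewhere, whereas here the loss of this single atom alone goes with a weaker inhibitor on an otherwise unchanged core. The step is modest, though beyond the scatter, and repeated entries for a single compound in this assay lie apart by a similar distance, so its size should be read with some caution: the several entries of compound 1 in this assay, 19100 nM; 41900 nM (2 entries)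

The compounds shown leave open how a fluoro, a methoxy or an amine at this same place would compare with chloro and hydrogen. Within the data shown here, they also leave open whether the same change would give a similar step on the core of compound 2, with its different substituents, since only one pair carries this difference.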